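A few compounds are considered here, and "the series" means these few. Any claim that something is new, unique, unknown or untested is made for them only; others in the source may bear on it.

Measured so far in a functional assay on HepG2 cells (Homo sapiens) for inhibition, read by MTT assay, with a stated time of 72 h; a lower number here means a stronger inhibitor, a higher number a weaker inhibitor:
compound 1, `O=C(Nc1ccc(Oc2ccnc3[nH]ccc23)cc1)c1cn(-c2ccc(Br)cc2F)c2ccccc2c1=O`, gives 790 nM
compound 2, `O=C(Nc1ccc(Oc2ccnc3[nH]ccc23)c(F)c1)c1cn(-c2ccc(Br)cc2)c2ccccc2c1=O`, gives 710 nM

On these two numbers compound 2 and compound 1 sit within the scatter of each other, so no order between them can be drawn from this assay; compound 2 simply carries the smaller of two numbers that cannot be told apart.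

Compound 3, `O=C(Nc1ccc(Oc2ccnc3[nH]ccc23)c(F)c1)c1cn(-c2ccc(Br)cc2F)c2ccccc2c1=O`, has not yet been tested in this assay. It differs from compound 2 in one place: fluoro in place of hydrogen on an aromatic carbon. Among the compounds with values here, no pair of measured compounds differs in exactly this way, so the size of such a step is not known from the series itself. With both measured compounds at the same level, the expected step is a 1.1-fold lower number from compound 2 to compound 3 (0.04 log units; within the scatter), which stays within the scatter rather than marking a real move in either direction. Compound 3 is therefore estimated at 650 nM in this assay, with a range from 300 nM to 1500 nM.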

Compound 3, half-maximal inhibitory concentration: 2200 nM
Beside the measured number, compound 3's estimate is 3.4-fold (0.53 log units) below it; the measured number lies above the stated range.
By their numbers in this assay, from the lowest: compounds 2 and 1 (each within the scatter of the next); then compound 3.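

In this assay, the change from 4-bromophenyl to 4-bromo-2-fluorophenyl, which puts a fluoro ortho to a large group and meta to a bromo group, weakens the compound (a 3.1-fold higher number from compound 2 to compound 3 (0.49 log units; beyond the scatter)). Fluoro in place of hydrogen on the other aromatic ring, in a compound already carrying 4-bromo-2-fluorophenyl, also weakens it (a 2.8-fold higher number from compound 1 to compound 3 (0.44 log units; beyond the scatter)), so within these three compounds the second fluoro costs activity at either place. Nothing at hand accounts for this loss.

On these data alone, whether a chloro, a methoxy or an amine at the same position on the bromophenyl ring would give a similar step remains open. Also open, as far as these compounds go, is whether the step persists when the bromo group is replaced by a methyl or a nitrile.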